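Adding a Methoxy Group to the Benzyl Amide

The source may hold more compounds than are shown below. What is called first, only, known or untested is meant among the compounds shown, and "the series" means these compounds.

Measured so far:
- Compound 1, `COc1ccc(CNC(=O)c2cc(Oc3ccc(/C=C/c4ccccn4)cc3)ccn2)cc1`: 63600 nM
- Compound 2, `CNC(=O)c1cc(Oc2ccc(/C=C/c3ccncc3)cc2)ccn1`: 13200 nM
- Compound 3, `O=C(NCc1ccccc1)c1cc(Oc2ccc(/C=C/c3ccncc3)cc2)ccn1`: 17000 nM

In a functional assay on A549 cells (Homo sapiens) for antiproliferative activity, read by CCK-8 assay, with a stated time of 48 h (on this read-out higher numbers stand for weaker inhibition and lower numbers for stronger inhibition), compound 3 gives 17000 nM, the second highest of the three numbers; its closest neighbour is compound 2, whose number is lower by a margin within the scatter, while compound 1 is furthest away with a number beyond the scatter above it. The next compound, compound 4, `COc1ccc(CNC(=O)c2cc(Oc3ccc(/C=C/c4ccncc4)cc3)ccn2)cc1`, is made from compound 3 by a single change: methoxy in place of hydrogen on an aromatic carbon.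

Going by the values given here, only one measured step is directly comparable in spirit, the change of the amide substituent from compound 2 to compound 3, which gave a 1.3-fold higher number from compound 2 to compound 3 (0.11 log units; within the scatter). That step shows the amide side of the shared core tolerating a larger group without a shift beyond the scatter. Compound 1 also carries the (4-methoxybenzyl)amino group, yet it differs from compound 4 elsewhere in the molecule. In this assay compound 1 gives 63600 nM, which can only hint that methoxybenzyl analogues in this series have not reached low numbers. On that basis compound 4 is expected to show a modest weakening, a 1.5-fold higher number from compound 3 to compound 4 (0.17 log units; within the scatter), likely within or just at the edge of the scatter. The estimate for compound 4 is 25000 nM, with a range from 8000 nM to 70000 nM.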

Compound 4, half-maximal inhibitory concentration: 19300 nM
Compound 4: the middle estimate sits 1.3-fold (0.11 log units) above what was measured, within the range that was stated.
By their numbers in this assay, from the lowest: compounds 2, 3 and 4 (each within the scatter of the next); then compound 1.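

In this assay, swapping benzyl for 4-methoxybenzyl, with the methoxy para to a large group, gives a 1.1-fold higher number from compound 3 to compound 4 (0.06 log units; within the scatter) and so shows that this position accepts a methoxy without a change that can be told from the scatter. Measured from the small amide end, the same larger group gives a 1.5-fold higher number from compound 2 to compound 4 (0.16 log units; within the scatter) and this places compounds 2, 3 and 4 within the scatter of one another, so neither the benzyl group nor its methoxy has yet moved the number in a way that can be read. With the 4-methoxybenzyl amide held fixed, pyridin-4-yl in place of pyridin-2-yl gives a 3.3-fold lower number from compound 1 to compound 4 (0.52 log units; beyond the scatter) and this shows that the high number of compound 1 goes with its pyridin-2-yl group rather than with the methoxybenzyl amide.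

Still open, as far as these compounds go, is whether an amine, a carboxylic acid or a longer chain in place of the methoxy on this ring would move the number beyond the scatter, and whether the pyridine step would be the same size with a benzyl or methyl amide. No supporting measurement bears on why any of these numbers fall as they do.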